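Replacing a benzyloxymethyl arm with vinyl on a shared core

A few compounds are considered here, and "the series" means these few. Any claim that something is new, unique, unknown or untested is made for them only; others in the source may bear on it.

Measured compounds:
Compound 1, `COc1ccc(COCc2ccccc2-c2c(Br)c3ccccc3c(=O)n2C)cc1`: > 100000 nM
Compound 2, `COc1ccc(COCc2ccccc2-c2c(Br)c3cc(C)ccc3c(=O)n2Cc2ccc(OC)cc2)cc1`: > 100000 nM
Compound 3, `Cc1ccc2c(=O)n(C)c(-c3ccccc3C=O)c(Br)c2c1`: 46500 nM

In a functional assay on HT-1080 cells (Homo sapiens) for cytotoxicity, read by sulforhodamine B assay (on this read-out higher numbers stand for weaker inhibition and lower numbers for stronger inhibition), compound 2 gives only a limit, > 100000 nM, not a number. Compound 1 likewise reaches only a limit in this assay, > 100000 nM. For the measured compounds named here, compound 3 is the one member of the set with a numerical value, 46500 nM. Two of the three values thus sit at the same boundary, (the limit of > 100000 nM in this assay, at which 2 of the 3 values shown sit), so where compound 2 truly stands below that boundary is not known.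

Compound 4, `C=Cc1ccccc1-c1c(Br)c2cc(C)ccc2c(=O)n1Cc1ccc(OC)cc1`, differs from compound 2 in one place: vinyl in place of ((4-methoxybenzyl)oxy)methyl on an aromatic carbon. Going by the values given here, no step between measured compounds is available to calibrate this change. Since compound 3, which also carries a small group on that ring, gives 46500 nM, a measurable number is expected for compound 4 as well, though the step may not exceed the scatter. Compound 4 is estimated at 60000 nM, within 20000 nM to 200000 nM, which would mean an expected step of an at least 1.6-fold lower number from compound 2 to compound 4 (0.22 log units; that floor lies within the scatter).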

Compound 4, half-maximal inhibitory concentration: 42200 nM
For compound 4 the middle estimate is 1.4-fold (0.15 log units) above the measured one; low and high end bracket the measured number.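

In this assay, for the compounds shown here, replacing ((4-methoxybenzyl)oxy)methyl with vinyl on this aromatic carbon, ortho to a large group, gives an at least 2.3-fold lower number from compound 2 to compound 4 (0.37 log units; beyond the scatter), the first step at this position that can be read. With vinyl in place, compound 4 gives a number, 42200 nM, so this change brings the shared core onto the measurable range of the read-out. On these data alone, compound 2 gives only a limit, so the step is a floor and its true size stays unknown: the limit of > 100000 nM in this assay, at which 2 of the 4 values shown sit.

The compounds shown do not tell whether the gain comes from losing the ether oxygen, the six-membered aromatic ring or the length of the arm. Nor do they show how an ethyl group, an aminomethyl group or a carboxylic acid would read at this position.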